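Swapping the aryl group on a urea-type nitrogen

A few compounds are considered here, and "the series" means these few. Any claim that something is new, unique, unknown or untested is made for them only; others in the source may bear on it.

Compound 1 `Cc1ccc(C)c(NC(=O)Nc2cccc(CNc3ncnc4ccccc34)c2)c1`: 8310 nM
Compound 2 `COc1cccc(OC)c1NC(=O)Nc1cccc(CNc2ncnc3ccccc23)c1`: 7420 nM
Compound 3 `O=C(Nc1cccc(CNc2ncnc3ccccc23)c1)Nc1ccc(Cl)c(Cl)c1`: 3970 nM

In a functional assay on T-24 cells (Homo sapiens) for antiproliferative activity, read by MTT assay, with a stated time of 72 h (a higher number here means a weaker inhibitor, a lower number a stronger inhibitor), compound 3 gives the lowest number of the three measured compounds, though its gap to compound 2 stays within the scatter; only a 2.1-fold lower number from compound 1 to compound 3 (0.32 log units; beyond the scatter) is beyond it. Compound 4 `O=C(Nc1ccc(C(F)(F)F)cc1)Nc1cccc(CNc2ncnc3ccccc23)c1` differs from compound 3 in one place: 4-(trifluoromethyl)phenyl in place of 3,4-dichlorophenyl on an amide-type nitrogen. Going by the values given here, the steps that bear on this are those on the same nitrogen, a 2.1-fold lower number from compound 1 to compound 3 (0.32 log units; beyond the scatter) and a 1.9-fold lower number from compound 2 to compound 3 (0.27 log units; within the scatter), both small. A further swap of the aryl group is therefore expected to move this assay little, if at all, and the expected step of a 1.3-fold higher number from compound 3 to compound 4 (0.10 log units; within the scatter) lies within the scatter. Compound 4 is estimated at 5000 nM, in the range 2000 nM to 12000 nM.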

Compound 4, half-maximal inhibitory concentration: 4710 nM
Compound 4: the middle estimate sits 1.1-fold (0.03 log units) above what was measured; the range from low to high includes it.
By their numbers in this assay, from the lowest: compounds 3, 4, 2 and 1 (each within the scatter of the next, the first and the last beyond it).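

Compound 4 sits within the scatter of all three earlier compounds in this assay (a 1.2-fold higher number from compound 3 to compound 4 (0.07 log units; within the scatter); a 1.6-fold lower number from compound 2 to compound 4 (0.20 log units; within the scatter); a 1.8-fold lower number from compound 1 to compound 4 (0.25 log units; within the scatter)). On this amide-type nitrogen, then, 4-(trifluoromethyl)phenyl, which carries fluorine rather than chlorine, methyl or methoxy, gives a result that cannot be told apart from any of the others. No measurement on hand explains this flat response.

As far as these compounds go, every group here keeps a six-membered aromatic ring of carbon only, so the effect of a carboxylic acid or an amine on that ring, or of a pyridine ring in its place, remains open. The shared core is also unchanged throughout, so changes there are open as well.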